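What a sulfonyl group might do to compound 2

The compounds below may be only part of what the source reports. "The series", "measured", "known", "first", "only" and "open" are said of these compounds alone.

Of the compounds shown here, two have been measured so far in a functional assay on HepG2 cells (Homo sapiens) for cytotoxicity, read by MTT assay, with a stated time of 24 h; a higher number here means a weaker inhibitor, a lower number a stronger inhibitor. Compound 1 (`COc1cc(/C=C2\CN(C)C/C(=C\c3ccncc3)C2=O)cc(OC)c1OC`) comes in at 9800 nM on this scale, and compound 2 (`O=C1/C(=C/c2cccnc2)CNC/C1=C\c1ccccc1F`) at 21000 nM on the same scale. Compound 2 therefore holds the higher of the two numbers, which makes it the weaker inhibitor of the pair, and the gap lies beyond the usual scatter of repeated measurements.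

Compound 3 (`O=C1/C(=C/c2cccnc2)CN(S(=O)(=O)c2ccc(Cl)cc2)C/C1=C\c1ccccc1F`) matches compound 2 except at one place, where (4-chlorophenyl)sulfonyl stands in place of hydrogen on an amine nitrogen in a ring ((4-chlorophenyl)sulfonyl in place of hydrogen on an amine nitrogen in a ring). Within the data shown here, no measured pair shows this change on its own. The only hint is thin: compound 1 at 9800 nM also carries a group on that ring nitrogen and reads lower, but it differs from compound 2 elsewhere too, so the gap cannot be pinned on the nitrogen alone.

The step expected is a 3.5-fold lower number from compound 2 to compound 3 (0.54 log units; beyond the scatter) in the direction of a stronger inhibitor, though with little certainty. The estimate for compound 3 is 6000 nM with an expected range from 1500 nM to 24000 nM for this reading.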

Compound 3, half-maximal inhibitory concentration: 12400 nM
Compound 3: the middle estimate sits 2.1-fold (0.32 log units) below what was measured, and the stated range covers the measured number.
By their numbers in this assay, from the lowest: compounds 1, 3 and 2 (each within the scatter of the next, the first and the last beyond it).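

Among these compounds, this is the first direct reading of a change at the amine nitrogen in the six-membered non-aromatic ring, and in this assay the result is a 1.7-fold lower number from compound 2 to compound 3 (0.23 log units; within the scatter) with (4-chlorophenyl)sulfonyl in place of hydrogen. Adding this group of 10 heavy atoms, with its own aromatic ring, therefore leaves the reading indistinguishable from that of the unsubstituted nitrogen, so this single pair shows that the position can carry a large sulfonyl group without a clear gain or loss in this cytotoxicity reading. Nothing offered here explains why the reading stays within the scatter, and no measurement of any property of the group bears on the result.

A single substituent at this nitrogen cannot show whether the sulfonyl link, the aromatic ring or the chlorine matters most, and a close comparison would need a group such as methylsulfonyl, phenylsulfonyl or benzoyl on the same core. From the compounds shown here alone, it also remains open whether an acetyl group or a longer alkyl chain at this nitrogen would move the reading beyond the scatter in either direction.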